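Indol-3-yl in place of furan-2-yl on the carbonyl carbon

This account rests on a few compounds, and the source may have more. Where it says the series, first, only, none or still open, it means among the compounds named here.

The three measured compounds share one core and differ at the group attached to it. Compound 1 `COc1ccc(-c2cc3ccccc3nc2C=O)cc1` carries a formyl group there. In a functional assay on H184B5F5/M10 cells (Homo sapiens) for antiproliferative activity, read by XTT assay, with a stated time of 72 h (a higher number here means a weaker inhibitor, a lower number a stronger inhibitor), compound 1 gives only a limit, > 10000 nM (the limit of > 10000 nM in this assay, at which 1 of the 3 values shown sits). Compound 2 `COc1ccc(-c2cc3ccccc3nc2/C=C/C(=O)c2ccc(N)cc2)cc1` gives 9290 nM in this assay. Compound 3 `COc1ccc(-c2cc3ccccc3nc2/C=C/C(=O)c2ccco2)cc1` gives 6240 nM in this assay, the lowest of the two numbers shown, though its gap to compound 2 stays within the scatter. The steps into compound 3 are small: an at least 1.6-fold lower number from compound 1 to compound 3 (0.20 log units; that floor lies within the scatter), and a 1.5-fold lower number from compound 2 to compound 3 (0.17 log units; within the scatter).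

Compound 4 `COc1ccc(-c2cc3ccccc3nc2/C=C/C(=O)c2c[nH]c3ccccc23)cc1` differs from compound 3 at the same position as the second of these steps: 1H-indol-3-yl in place of furan-2-yl on a carbonyl carbon. Among the compounds with values here, the only step measured at this position, a 1.5-fold lower number from compound 2 to compound 3 (0.17 log units; within the scatter), stayed within the scatter, and the step from compound 1 reached no further. A change on the carbonyl carbon is therefore expected to move the number little, in either direction. Compound 4 is estimated to give about 4500 nM in this assay, with a range from 1500 nM to 13000 nM. This estimate means a step of a 1.4-fold lower number from compound 3 to compound 4 (0.14 log units; within the scatter), which is expected to remain within the scatter.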

Compound 4, half-maximal inhibitory concentration: > 10000 nM
Compound 4 ended at the assay's limit; the forecaster's own chance of this, stated with the estimate: 20%; middle value at least 2.2-fold (0.34 log units) away from the limit.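

Compound 4 gives > 10000 nM in this assay, which is a limit of the assay and not a number, and it shares that limit with compound 1: the limit of > 10000 nM in this assay, at which 2 of the 4 values shown sit. With 1H-indol-3-yl on the carbonyl carbon, the number did not fall, and the steps are an at least 1.6-fold higher number from compound 3 to compound 4 (0.20 log units; that floor lies within the scatter) and an at least 1.0-fold higher number from compound 2 to compound 4 (0.03 log units; that floor lies within the scatter). Unlike the earlier compounds carrying a group on this carbonyl carbon, compound 4 shows that such a group can leave the reading at the limit, although both floors stay within the scatter.

On these data alone, how far compound 4 lies beyond the limit remains unknown, so the true size of both steps is open. Also open, as far as these compounds go, is whether an amine, a carboxylic acid or a longer chain on the carbonyl carbon would move the number beyond the scatter from compound 3 .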